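The compounds below may be only part of what the source reports. "The series", "measured", "known", "first", "only" and "open" are said of these compounds alone.

Compound 2 `CCCCCC(=O)c1ccc(OCCCN2CCN(C(=O)C(C)C)CC2)cc1` gives 29500 nM in an assay on isolated protein for binding affinity to histamine H2 receptor (Homo sapiens) (a higher number here means a weaker inhibitor, a lower number a stronger inhibitor), the higher of the two numbers measured, while compound 1 `CCCCCC(=O)c1ccc(OCCCN2CCN(C(=O)OCC(C)C)CC2)cc1` gives 3720 nM. For the measured compounds named here, the one step measured, a 7.9-fold higher number from compound 1 to compound 2 (0.90 log units; beyond the scatter), exchanges the whole group on the carbonyl carbon and so bears only loosely on compound 3 `CCCCCC(=O)c1ccc(OCCCN2CCN(C(=O)C(C)(C)O)CC2)cc1`, which differs from compound 2 by hydroxy in place of hydrogen on a saturated chain carbon bound to a carbonyl carbon and two saturated chain carbons. Going by the values given here, no measured pair exchanges a hydrogen for a hydroxy, so the direction of the step is uncertain; a small shift toward a lower number is expected, a 1.6-fold lower number from compound 2 to compound 3 (0.21 log units; within the scatter), with compound 3 estimated at 18000 nM, within 5000 nM to 60000 nM.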

Compound 3, inhibition constant: 24500 nM
For compound 3 the middle estimate is 1.4-fold (0.13 log units) below the measured one; the measured number falls inside the stated range.
By their numbers in this assay, from the lowest: compound 1; then compounds 3 and 2 (each within the scatter of the next).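

In this assay, hydroxy in place of hydrogen on this saturated chain carbon gives a 1.2-fold lower number from compound 2 to compound 3 (0.08 log units; within the scatter), so this exchange leaves the reading unmoved within the scatter. 1-Hydroxy-1-methylethyl in place of isobutoxy on the carbonyl carbon gives a 6.6-fold higher number from compound 1 to compound 3 (0.82 log units; beyond the scatter), so the hydroxy does not close the gap to the isobutoxy group. No supporting evidence bears on this result. The compounds shown leave open whether an amine or a carboxylic acid on this carbon would move the number, and whether a longer chain there would.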